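The source may hold more compounds than are shown below. What is called first, only, known or untested is meant among the compounds shown, and "the series" means these compounds.

Of the compounds shown here, two have so far been measured in an ADME assay on the whole organism for pharmacokinetics, with Rattus norvegicus as the target, with a stated time of 6 h, at a dose of 10 mg/kg by the oral route; a lower number here means less compound in the circulation, a higher number more compound in the circulation at the dose given. Compound 1 `Cc1cn2c(-c3cn[nH]c3)cnc2c(Nc2cc(Cc3ncccn3)ns2)n1` gives 701 ng.h/mL in this assay. Among the compounds with values here, compound 2 `Cc1cn2c(-c3cn[nH]c3)cnc2c(Nc2cc(Cc3ccc(F)cn3)ns2)n1` gives 2240 ng.h/mL in this assay, which is the higher of the two numbers; the single measured step, a 3.2-fold higher number from compound 1 to compound 2 (0.50 log units; beyond the scatter), lies beyond the scatter.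

Compound 3 `COc1cccc(Cc2cc(Nc3nc(C)cn4c(-c5cn[nH]c5)cnc34)sn2)n1` has not yet been measured. It differs from compound 2 in one place: 6-methoxypyridin-2-yl in place of 5-fluoropyridin-2-yl on a saturated chain carbon bound to an aromatic carbon. Within the data shown here, the only measured step that bears on this change is the one from compound 1 to compound 2, which also exchanged the aromatic ring sitting on the same saturated chain carbon and gave a 3.2-fold higher number from compound 1 to compound 2 (0.50 log units; beyond the scatter). Among the measured compounds shown here, that step, however, replaced one kind of ring by another, whereas the present change keeps a six-membered aromatic ring with one hetero atom and only alters the substituent carried on it, for which no measured step exists. A small shift in either direction cannot be ruled out, so the expected step is a 1.4-fold lower number from compound 2 to compound 3 (0.15 log units; within the scatter), not beyond the scatter. Compound 3 is therefore estimated at 1600 ng.h/mL in this assay, with a range from 500 ng.h/mL to 5000 ng.h/mL.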

Compound 3, area under the concentration-time curve: 2300 ng.h/mL
The estimate for compound 3 lay 1.4-fold (0.16 log units) below the measured number; low and high end bracket the measured number.
By their numbers in this assay, from the lowest: compound 1; then compounds 2 and 3 (each within the scatter of the next).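

The swap of 5-fluoropyridin-2-yl for 6-methoxypyridin-2-yl on the saturated chain carbon gives a 1.0-fold higher number from compound 2 to compound 3 (0.01 log units; within the scatter) in this assay, so the two numbers cannot be told apart, even though the ring carries a different substituent and the group that enters holds oxygen instead of fluorine. Compound 3 also stands clear of the pyrimidin-2-yl compound, with a 3.3-fold higher number from compound 1 to compound 3 (0.52 log units; beyond the scatter) in this assay, which means the earlier gap is not tied to the 5-fluoropyridin-2-yl group alone: two differently substituted pyridine rings now both sit above compound 1. No measurement shown here says what lies behind these numbers.

The compounds shown leave open whether the ring needs a substituent at all, since plain pyridin-2-yl is not among them, and whether the tolerance seen here would hold for a very different substituent such as an amine or a carboxylic acid. They also leave open what a longer chain in place of the single saturated carbon would do to the amount of compound in the circulation.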